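Removing a tert-butyl group from a cytotoxic thiazolidinedione

The source may report more compounds than this note shows. Statements on the series, on what has been measured and on what is new or still open speak of the compounds shown alone.

Compound 1 `CC(C)(C)c1ccc(CN2C(=O)S/C(=C\c3ccc(N)cc3)C2=O)cc1` is the stronger of two measured compounds. In a functional assay on HeLa cells (Homo sapiens) for cytotoxicity, read by cell counting, with a stated time of 4 days (a lower number here means a stronger inhibitor, a higher number a weaker inhibitor), compound 1 gives 53000 nM, the lowest of the two numbers recorded. For the measured compounds named here, its companion compound 2 `CC(C)(C)c1ccc(CN2C(=O)S/C(=C\c3cccc(N)c3)C2=O)cc1` carries the amino group at a different ring position; in this assay compound 2 gives 145000 nM, and the step of a 2.7-fold higher number from compound 1 to compound 2 (0.44 log units; beyond the scatter) is the only measured change in this set. Compound 3 `Nc1ccc(/C=C2\SC(=O)N(Cc3ccccc3)C2=O)cc1` differs from compound 1 elsewhere: hydrogen in place of tert-butyl on an aromatic carbon. Going by the values given here, no measured step touches this tert-butyl group, so the one recorded step offers no direct guide, and only the general observation that a single change here moved the number modestly can be carried over. A small weakening, or no step beyond the scatter, is therefore expected, a 1.9-fold higher number from compound 1 to compound 3 (0.28 log units; within the scatter). Compound 3 is estimated at 100000 nM, within a range from 30000 nM to 300000 nM.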

Compound 3, half-maximal inhibitory concentration: 46000 nM
Beside the measured number, compound 3's estimate is 2.2-fold (0.34 log units) above it; low and high end bracket the measured number.
By their numbers in this assay, from the lowest: compounds 3 and 1 (each within the scatter of the next); then compound 2.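

In this assay, putting hydrogen in place of tert-butyl on this aromatic carbon gives a 1.2-fold lower number from compound 1 to compound 3 (0.06 log units; within the scatter), so the two compounds cannot be told apart. In this one comparison, the four carbons of the tert-butyl group can go without any step beyond the scatter, which makes this position less sensitive to this change than the amino group's ring position was to its move, a 2.7-fold higher number from compound 1 to compound 2 (0.44 log units; beyond the scatter) in the same assay. No available evidence bears on why the number holds when this group is removed.

As far as these compounds go, it remains open whether a more different group on this aromatic carbon, such as a carboxylic acid or an amine, would shift the number beyond the scatter. From the compounds shown here alone, it is also open whether moving the amino group would give a similar step in a compound that has hydrogen here instead of tert-butyl.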